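Cytotoxicity on Vero cells: methyl for chloro on the core

A few compounds are considered here, and "the series" means these few. Any claim that something is new, unique, unknown or untested is made for them only; others in the source may bear on it.

compound 1, `COc1ccc(CNc2ncnc(-c3ccco3)c2NC=O)cc1`: > 40 ug/mL
compound 2, `COc1ccc(CNc2nc([N+](=O)[O-])nc(-c3ccco3)c2NC=O)cc1`: > 40 ug/mL
compound 3, `COc1ccc(CNc2nc(Cl)nc(-c3ccco3)c2NC=O)cc1`: > 40 ug/mL

In an ADME assay on Vero cells (Chlorocebus sabaeus) for cytotoxicity, read by MTT assay, with a stated time of 72 h (a lower number here means a stronger inhibitor, a higher number a weaker inhibitor), compound 3 stands at > 40 ug/mL, which is a limit of the assay and not a number. Compound 1 likewise returns a limit at > 40 ug/mL. Compound 2 also returns a limit at > 40 ug/mL. All three sit at the limit of > 40 ug/mL in this assay, at which 3 of the 3 values shown sit, so the steps a step that the two limits leave unreadable from compound 1 to compound 2, a step that the two limits leave unreadable from compound 1 to compound 3 and a step that the two limits leave unreadable from compound 2 to compound 3 cannot be sized.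

Compound 4, `COc1ccc(CNc2nc(C)nc(-c3ccco3)c2NC=O)cc1`, differs from compound 3 by methyl in place of chloro on an aromatic carbon. For the measured compounds named here, the steps that bear on this change are all unreadable, so no step beyond the scatter is expected for a step that the limit leaves unreadable from compound 3 to compound 4. Compound 4 is therefore estimated at 60 ug/mL, with a range from 30 ug/mL to 200 ug/mL, and most likely reported as a limit again.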

Compound 4, half-maximal inhibitory concentration: > 40 ug/mL
Compound 4: only a limit was reported (the forecaster's own chance of this, stated with the estimate: 85%); the middle value lies beyond the limit too.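

For the compounds shown here, compound 4 reads as a limit, as do compound 1, compound 2 and compound 3, so no step among them can be read: the limit of > 40 ug/mL in this assay, at which 4 of the 4 values shown sit. From the compounds shown here alone, whether hydrogen, nitro, chloro or methyl at this place differ at all in this assay stays open.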